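Aryl substituent variation on the shared core: compound 4

This account rests on a few compounds, and the source may have more. Where it says the series, first, only, none or still open, it means among the compounds named here.

The shared core of compound 1 `CCC1=C(O)c2c(oc(-c3ccc(CC)cc3)cc2=O)C(CC)(CC)C1=O` carries an aryl group that is varied across the series. In a functional assay on KB cells (Homo sapiens) for antiproliferative activity, read by sulforhodamine B assay, with a stated time of 3 days (on this read-out higher numbers stand for an effect only at larger amounts of compound and lower numbers for an effect already at smaller amounts), compound 1 gives 21.9 uM, the highest of the three numbers. Compound 2 `CCC1=C(O)c2c(oc(-c3ccc(O)cc3)cc2=O)C(CC)(CC)C1=O` gives 20.6 uM in this assay, and compound 3 `CCC1=C(O)c2c(oc(-c3cccc(OC)c3)cc2=O)C(CC)(CC)C1=O` gives 13.3 uM. The steps between them are small: a 1.1-fold lower number from compound 1 to compound 2 (0.03 log units; within the scatter), a 1.6-fold lower number from compound 1 to compound 3 (0.22 log units; within the scatter) and a 1.5-fold lower number from compound 2 to compound 3 (0.19 log units; within the scatter), each within the scatter, so the three aryl groups tried so far give no separation.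

Compound 4 `CCC1=C(O)c2c(oc(-c3ccccc3C)cc2=O)C(CC)(CC)C1=O` is not yet measured. Relative to compound 1 the change is 2-methylphenyl in place of 4-ethylphenyl on an aromatic carbon. Within the data shown here, no measured step tests a 2-methylphenyl group; the steps that bear on it are the aryl changes from compound 1 to compound 2 and from compound 1 to compound 3, both within the scatter. The step expected in this assay is therefore none beyond the scatter, a 1.1-fold lower number from compound 1 to compound 4 (0.04 log units; within the scatter). Compound 4 is estimated at 20 uM, with an expected range from 8 uM to 50 uM.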

Compound 4, concentration for half-maximal effect: 40.9 uM
The estimate for compound 4 lay 2.0-fold (0.31 log units) below the measured number, and the stated range covers the measured number.
By their numbers in this assay, from the lowest: compounds 3, 2, 1 and 4 (each within the scatter of the next, the first and the last beyond it).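

In this assay, among these compounds, the aryl group on the shared core now gives its first separation: 2-methylphenyl against 3-methoxyphenyl gives the only step beyond the scatter (a 3.1-fold higher number from compound 3 to compound 4 (0.49 log units; beyond the scatter)). Against the other two aryl groups, 2-methylphenyl gives no separation (a 1.9-fold higher number from compound 1 to compound 4 (0.27 log units; within the scatter); a 2.0-fold higher number from compound 2 to compound 4 (0.30 log units; within the scatter)), so compound 4 stands apart from compound 3 alone, and the change from 4-ethylphenyl seen in compound 1 cannot be called a loss. No measurement available here accounts for the separation from compound 3.

Among the compounds shown here, compound 4 is the only compound with a methyl group on this aryl ring, so the effect of where that group sits remains open. Also open, on these data alone, is how an aryl ring carrying an amine or a carboxylic acid would read in this assay.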